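The source may report more compounds than this note shows. Statements on the series, on what has been measured and on what is new or still open speak of the compounds shown alone.

Among the compounds with values here, compound 3, `O=C(OCCc1c(-c2ccccc2Cl)c2cc(Cl)ccc2[nH]c1=O)c1cccnc1`, gives 170000 nM in an ADME assay on HepG2 2.2.15 cells (Homo sapiens) for cytotoxicity (a higher number here means that more compound is tolerated, a lower number that less compound is tolerated), which is the highest of the three numbers measured so far; compound 2, `O=C(CCC1CCCCC1)OCCc1c(-c2ccccc2Cl)c2cc(Cl)ccc2[nH]c1=O`, gives 160000 nM, and a 1.1-fold higher number from compound 2 to compound 3 (0.03 log units; within the scatter), while compound 1, `CCCC(=O)OCCc1c(-c2ccccc2Cl)c2cc(Cl)ccc2[nH]c1=O`, gives 52000 nM, and a 3.3-fold higher number from compound 1 to compound 3 (0.51 log units; beyond the scatter). Compound 4, `COc1ccc(/C=C/C(=O)OCCc2c(-c3ccccc3Cl)c3cc(Cl)ccc3[nH]c2=O)cc1`, differs from compound 3 at the same position that separates compounds 1, 2 and 3 from one another: 2-(4-methoxyphenyl)ethenyl in place of pyridin-3-yl on a carbonyl carbon. The two earlier changes on that carbonyl carbon bear on it. Going from propyl to a bulkier substituent raised the number modestly, as a 3.1-fold higher number from compound 1 to compound 2 (0.49 log units; beyond the scatter) and a 3.3-fold higher number from compound 1 to compound 3 (0.51 log units; beyond the scatter) show, whereas swapping one bulkier substituent for another, a 1.1-fold higher number from compound 2 to compound 3 (0.03 log units; within the scatter), stayed within the scatter. Since the new group is another large substituent on the same carbonyl carbon, compound 4 is expected to sit near compound 3, with no change at the digits printed from compound 3 to compound 4 (within the scatter) expected to remain within the scatter. Compound 4 is therefore estimated at 170000 nM in this assay, with a range from 70000 nM to 400000 nM.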

Compound 4, half-maximal cytotoxic concentration: > 1200000 nM
Compound 4 was reported as a limit; the forecaster's own chance of this, stated with the estimate: 25%; middle value at least 7.0-fold (0.84 log units) away from the limit.
By their numbers in this assay, from the lowest: compound 1; then compounds 2 and 3 (each within the scatter of the next). At a limit, above all of these: compound 4.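

In this assay, compound 4 is known only as a limit: the limit of > 1200000 nM in this assay, at which 1 of the 4 values shown sits. Read against that limit, the step on this carbonyl carbon is an at least 7.0-fold higher number from compound 3 to compound 4 (0.84 log units; beyond the scatter), an at least 7.5-fold higher number from compound 2 to compound 4 (0.87 log units; beyond the scatter) and an at least 23-fold higher number from compound 1 to compound 4 (1.36 log units; beyond the scatter). The earlier compounds shown here showed pyridin-3-yl and 2-cyclohexylethyl within the scatter of each other, whereas this result shows that 2-(4-methoxyphenyl)ethenyl parts from both, so that not every large group at this position gives the same number.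

The compounds shown leave open how far compound 4 lies past its limit, and whether the double bond, the methoxy group or the aromatic ring carries the step. A saturated 2-(4-methoxyphenyl)ethyl group or an unsubstituted 2-phenylethenyl group on the same carbonyl carbon would bear on that question.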